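This account rests on a few compounds, and the source may have more. Where it says the series, first, only, none or still open, it means among the compounds named here.

Measured compounds:
Compound 1 `N#Cc1ccc(O/N=C2/C=C(C#Cc3ccccn3)CCC2)cc1F` — 56.1 nM
Compound 2 `N#Cc1ccc(F)cc1O/N=C1/C=C(C#Cc2ccccn2)CCC1` — 73.4 nM
Compound 3 `FCCOCO/N=C1/C=C(C#Cc2ccccn2)CCC1` — 8.41 nM

In an assay on brain (strain Sprague-Dawley) for displacement of a labelled ligand from metabotropic glutamate receptor 5 (Rattus norvegicus), with a stated time of 45 min (a lower number here means a stronger inhibitor, a higher number a weaker inhibitor), compound 3 gives the lowest of the three numbers. Compound 1 sits a good deal higher, and compound 2 higher still; both gaps are beyond the usual scatter. Compound 4 `CO/N=C1/C=C(C#Cc2ccccn2)CCC1` has not yet been measured. It differs from compound 3 in one place: hydrogen in place of 2-fluoroethoxy on a saturated chain carbon bound to an oxygen on an unsaturated carbon. Going by the values given here, no step between measured compounds tests this change, so the size of the step is open. With the oxime and the pyridinylethynyl-cyclohexenyl core unchanged, the shortened ether side chain is expected to move the number by little, so compound 4 is estimated at 10 nM, with a range from 3 nM to 35 nM, corresponding to an expected step of a 1.2-fold higher number from compound 3 to compound 4 (0.08 log units; within the scatter) that is not beyond the scatter.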

Compound 4, inhibition constant: 2.2 nM
Beside the measured number, compound 4's estimate is 4.5-fold (0.66 log units) above it; the whole stated range lies above it.
By their numbers in this assay, from the lowest: compound 4; then compound 3; then compounds 1 and 2 (each within the scatter of the next).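

In this assay, hydrogen in place of 2-fluoroethoxy on a saturated chain carbon bound to an oxygen on an unsaturated carbon gives a 3.8-fold lower number from compound 3 to compound 4 (0.58 log units; beyond the scatter), a modest step. The position therefore does not need the longer (2-fluoroethoxy)methyl group to reach a low number, since plain methyl gives a lower one. No measurement at hand explains this step.

The compounds shown leave open how an ethyl group or a 2-methoxyethyl chain would read here. They therefore cannot separate the effect of chain length from that of the fluorine.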